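Swapping the Carbonate Ester for Chloride on the Alkyne Chain

This account rests on a few compounds, and the source may have more. Where it says the series, first, only, none or still open, it means among the compounds named here.

Compound 1 `CCOC(=O)OCC#CCSc1c(SC)cnc2ccccc12`: in a functional assay on CCRF-CEM cells (Homo sapiens) for antiproliferative activity, with a stated time of 72 h (a higher number here means a weaker inhibitor, a lower number a stronger inhibitor), compound 1 gives 13.2 ug/mL.
Compound 2 `CSc1cnc2ccccc2c1SCC#CCOC(=O)c1ccc(C(=O)O)cc1`: compound 2 gives 14.5 ug/mL.
Compound 3 `CSc1cnc2ccccc2c1SCC#CCOC(=O)c1ccccc1`: compound 3 gives 22.2 ug/mL.

Compound 1 has the lowest of the three numbers, but its neighbours sit close: the step of a 1.1-fold higher number from compound 1 to compound 2 (0.04 log units; within the scatter) and the step of a 1.7-fold higher number from compound 1 to compound 3 (0.23 log units; within the scatter) both fall within the usual scatter, as does a 1.5-fold higher number from compound 2 to compound 3 (0.18 log units; within the scatter). None of the three compounds can therefore be set apart from the others, and the three measured changes, each a swap of a group on a carbonyl carbon or on an aromatic carbon, left the read-out essentially unchanged.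

Compound 4 `CSc1cnc2ccccc2c1SCC#CCCl` differs from compound 1 as follows: chloro in place of (ethoxycarbonyl)oxy on a saturated chain carbon bound to a triple-bonded carbon. The whole (ethoxycarbonyl)oxy group leaves and a single chloro enters. Going by the values given here, no measured step removes this group entirely, so the three measured steps bear on it only loosely; each of them stayed within the scatter. On that basis the expected step of a 1.1-fold higher number from compound 1 to compound 4 (0.06 log units; within the scatter) is small, with no clear direction. Compound 4 is estimated at 15 ug/mL, within 7 ug/mL to 32 ug/mL.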

Compound 4, concentration for 50% inhibition: 2.5 ug/mL
Estimate against measurement, compound 4: 6.0-fold (0.78 log units) above; the whole stated range lies above it.
By their numbers in this assay, from the lowest: compound 4; then compounds 1, 2 and 3 (each within the scatter of the next).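

Going by these compounds alone, this saturated chain carbon bound to a triple-bonded carbon is the first place where a change clearly moves the read-out: in this assay, the step is a 5.3-fold lower number from compound 1 to compound 4 (0.72 log units; beyond the scatter). Compounds 1, 2 and 3 all keep a carbonyl group joined through oxygen at this place and stay within the scatter of one another, whereas compound 4 loses that whole (ethoxycarbonyl)oxy group and carries a single chloro instead. No measurement shown here accounts for this drop in the number.

Still open, on these data alone, is whether the drop belongs to chloro itself or simply to the loss of the (ethoxycarbonyl)oxy group. Compounds with a hydroxyl group, a bromo group or an amine at this place could help separate those two readings.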